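Phenyl to dimethylamino on the propyl ether chain

The source may report more compounds than this note shows. Statements on the series, on what has been measured and on what is new or still open speak of the compounds shown alone.

The series shares one core and varies the group on the ether oxygen. Compound 1 `CCCCNc1nc(N)nnc1OCc1ccccc1OC` carries a substituted benzyl ether; in an assay on isolated protein for agonist activity at Toll-like receptor 8 (Homo sapiens) (a lower number here means that less compound is needed, a higher number that more compound is needed for the effect), compound 1 gives 640 nM. Compound 2 `CCCCNc1nc(N)nnc1OCc1ccccn1` carries a pyridylmethyl ether, and in this assay compound 2 gives 330 nM. Compound 3 `CCCCNc1nc(N)nnc1OCCCc1ccccc1` extends the chain to a phenylpropyl ether; in this assay compound 3 gives 1930 nM, the highest of the three numbers, with compound 1 nearest and compound 2 furthest, both gaps beyond the scatter. Only compounds 1, 2 and 3 have been measured, so no general rule on chain length or aromatic substitution can be drawn from them.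

Compound 4 `CCCCNc1nc(N)nnc1OCCCN(C)C` is the next member. Relative to compound 3 the change is dimethylamino in place of phenyl on a saturated chain carbon, three bonds along the chain from an oxygen on an aromatic ring. Within the data shown here, no step between two measured compounds touches the same position, so nothing in the measured set shows how this assay responds to a basic chain terminus in place of a phenyl ring. Given that compound 3 already stands at the weak end of the set with 1930 nM, the step of a 1.3-fold higher number from compound 3 to compound 4 (0.11 log units; within the scatter) is expected to be small, within the scatter or a modest move toward a higher number. The estimate for compound 4 in this assay is 2500 nM, with a range from 800 nM to 8000 nM.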

Compound 4, half-maximal effective concentration: 100 nM
Compound 4: the middle estimate sits 25-fold (1.40 log units) above what was measured, outside the stated range (below it).
By their numbers in this assay, from the lowest: compound 4; then compounds 2 and 1 (each within the scatter of the next); then compound 3.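

In this assay, the group on a saturated chain carbon, three bonds along the chain from an oxygen on an aromatic ring, strongly affects the read-out: dimethylamino in place of phenyl gives a 19-fold lower number from compound 3 to compound 4 (1.29 log units; beyond the scatter). The earlier compounds shown here all carried an aromatic ring on the ether chain, and 2-(dimethylamino)ethyl in place of pyridin-2-yl gives a 3.3-fold lower number from compound 2 to compound 4 (0.52 log units; beyond the scatter), so an aromatic ring on this chain is not required for a low number. No measurement at hand accounts for either step.

The phenyl-to-dimethylamino change removes a ring, reduces the heavy atoms and brings in a nitrogen all at once, so the contribution of each remains unresolved; a cyclohexyl group at the same place would separate loss of the aromatic ring from gain of the nitrogen, and a methoxy group would test whether another heteroatom can serve. The compounds shown also leave open how the amine itself and the chain carrying it can vary, for example with a pyrrolidine, a primary amine, or a longer or shorter chain.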